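Halogen swap on the benzimidazole sulfonamide: a fluoro-to-chloro step

The source may hold more compounds than are shown below. What is called first, only, known or untested is meant among the compounds shown, and "the series" means these compounds.

Working notes on a small sulfonamide series tested in a functional assay on MCF7 cells (Homo sapiens) for inhibition, read by MTT assay, with a stated time of 48 h; a lower number here means a stronger inhibitor, a higher number a weaker inhibitor.

Compound 1 `COc1cc(N(Cc2ccc(Cl)cc2)S(=O)(=O)c2ccc(C)cc2)cc(OC)c1OC` and compound 2 `COc1cc(N(Cc2ccc(F)cc2)S(=O)(=O)c2ccc(C)cc2)cc(OC)c1OC` share the trimethoxyphenyl sulfonamide core and differ only at the benzyl ring. In this assay compound 1 gives 18600 nM. In this assay compound 2 gives 19200 nM. The change between them, (chloro in place of fluoro on an aromatic carbon), produced a 1.0-fold lower number from compound 2 to compound 1 (0.01 log units; within the scatter), so the two values cannot be told apart.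

Compound 3 `Cc1ccc(S(=O)(=O)N(Cc2nc3ccccc3[nH]2)c2ccc(F)cc2)cc1` carries a different core; the difference between the two cores is not broken down here. In this assay, within the data shown here, compound 3 gives only a limit, > 50000 nM, and this is the one value that sits at the limit of > 50000 nM in this assay, at which 1 of the 3 values shown sits.

Compound 4 `Cc1ccc(S(=O)(=O)N(Cc2nc3ccccc3[nH]2)c2ccc(Cl)cc2)cc1` is not yet measured. It differs from compound 3 by chloro in place of fluoro on an aromatic carbon. Among the measured compounds shown here, this is the same change as the one from compound 2 to compound 1, on the same kind of place, and that earlier step was within the scatter. Compound 4 is therefore expected to stay near the limit of compound 3 because the same change gave a 1.0-fold lower number from compound 2 to compound 1 (0.01 log units; within the scatter) on the other core. The expectation rests on that single measured step and on the limit seen for compound 3, not on any further evidence. This expectation amounts to a step that the limit leaves unreadable from compound 3 to compound 4.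

In this assay compound 4 is expected to give about 60000 nM, most likely between 25000 nM and 150000 nM, and most likely reported again only as a limit.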

Compound 4, half-maximal inhibitory concentration: 38300 nM
Compound 4: middle estimate off by 1.6-fold (0.19 log units), on the high side; the measured number falls inside the stated range.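

With chloro in place of fluoro on the core of compound 3, this assay gives an at least 1.3-fold lower number from compound 3 to compound 4 (0.11 log units; that floor lies within the scatter), so on the evidence available this change produces no step beyond the scatter on this core, as was also the case on the core of compound 1. Going by these compounds, compound 3 gives > 50000 nM, which is a limit and not a number, so the printed step is only a floor and the true size of the step on this core remains unknown: the limit of > 50000 nM in this assay, at which 1 of the 4 values shown sits. Among these compounds, the result therefore does not show that the change carries over from one core to the other with the same size, only that the two readings can be set side by side: the same change on two cores in this assay, a 1.0-fold lower number (0.01 log units; within the scatter) from compound 2 to compound 1 and an at least 1.3-fold lower number (0.11 log units; that floor lies within the scatter) from compound 3 to compound 4; the limit leaves it open whether they differ.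

The compounds shown cover only fluoro and chloro at this place, so it remains open whether an amine, a carboxylic acid or a nitrile on an aromatic carbon of the same ring would move the number in this assay on either core. No pair shown differs at the core alone, so the contribution of the core itself cannot be read, and with only two pairs any rule for this change across the wider series remains untested.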